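This account rests on a few compounds, and the source may have more. Where it says the series, first, only, none or still open, it means among the compounds named here.

Measured so far, in an ADME assay on HepG2 cells (Homo sapiens) for cytotoxicity, with a stated time of 48 h; on this read-out lower numbers stand for stronger inhibition and higher numbers for weaker inhibition:

Compound 1 `COc1ccc(CSc2nnc(-c3cc([N+](=O)[O-])cc([N+](=O)[O-])c3)n2C)cc1` gives > 30000 nM, which is a limit of the assay and not a number.
Compound 2 `Cn1c(SCc2ccc(Cl)cc2)nnc1-c1cc([N+](=O)[O-])cc([N+](=O)[O-])c1` gives > 30000 nM, again a limit.
Compound 3 `COc1ccc(CSc2nnc(-c3cc([N+](=O)[O-])cc(C(F)(F)F)c3)n2Cc2ccccc2)cc1` gives > 30000 nM, also a limit.

Compound 1 and compound 2 differ in one place: chloro in place of methoxy on an aromatic carbon. The step that the two limits leave unreadable from compound 1 to compound 2 has no readable size, a consequence of the limit of > 30000 nM in this assay, at which 3 of the 3 values shown sit, so this change has not yet shown what it does to cytotoxicity.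

Compound 4 `O=[N+]([O-])c1cc(-c2nnc(SCc3ccc(Cl)cc3)n2Cc2ccccc2)cc(C(F)(F)F)c1` is not yet measured. It differs from compound 3 by chloro in place of methoxy on an aromatic carbon, the same change as that from compound 1 to compound 2, made at the same kind of place. The difference between the core of compound 1 and the core of compound 3 is not broken down here.

Compound 3 stands at > 30000 nM, a limit. Among the measured compounds shown here, on that, and on the flat picture of this assay so far, the step that the limit leaves unreadable from compound 3 to compound 4 is expected to be small. Compound 4 is therefore estimated at 40000 nM, most probably reported once more only as a limit.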

Compound 4, half-maximal inhibitory concentration: > 30000 nM
Compound 4: only a limit was reported; the forecaster's own chance of this, stated with the estimate: 85%; the middle value is on the limit's open side.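

No size can be read for the step from compound 3 to compound 4, since each of the two compounds gives a limit of the assay and not a number: the limit of > 30000 nM in this assay, at which 4 of the 4 values shown sit.

The compounds shown leave open what chloro in place of methoxy does in this assay, and whether any close relative would give a readable value there.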